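The compounds below may be only part of what the source reports. "The series", "measured", "known", "first", "only" and "open" are said of these compounds alone.

Compound 1 `COc1ccc2c(=O)c(/C=C/C(=O)Nc3ccccc3Cl)coc2c1` carries a 2-chlorophenyl group directly on its amide nitrogen. In a functional assay on A549 cells (Homo sapiens) for inhibition, read by MTT assay, with a stated time of 48 h (on this read-out lower numbers stand for stronger inhibition and higher numbers for weaker inhibition), compound 1 gives 29900 nM. Compound 2 `COc1ccc2c(=O)c(/C=C/C(=O)NCc3ccc(C)cc3)coc2c1` differs from it only in having a 4-methylbenzyl group in that place. In this assay compound 2 reaches only > 100000 nM, which is a limit of the assay and not a measured number. The step of an at least 3.3-fold higher number from compound 1 to compound 2 (0.52 log units; beyond the scatter) is therefore a lower bound, and it rests on (the limit of > 100000 nM in this assay, at which 1 of the 2 values shown sits). So compound 2 stands at the weak end of what has been measured, with no exact value of its own.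

Compound 3 `COc1ccc2c(=O)c(/C=C/C(=O)Nc3ccc(Cl)cc3)coc2c1` is the next compound, made from compound 2 by 4-chlorophenyl in place of 4-methylbenzyl on an amide-type nitrogen. Among the measured compounds shown here, this change puts an aromatic ring back directly onto the amide nitrogen, as in compound 1, and so it runs the one measured step in reverse. That step was at least modest in size, so a lower number in this assay is expected for compound 3, of roughly the same order as compound 1 gives. Compound 3 is estimated at 30000 nM, with a range from 10000 nM to 100000 nM. That expectation amounts to an at least 3.3-fold lower number from compound 2 to compound 3 (0.52 log units; beyond the scatter).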

Compound 3, half-maximal inhibitory concentration: > 100000 nM
Compound 3 was reported as a limit; the forecaster's own chance of this, stated with the estimate: 25%; middle value at least 3.3-fold (0.52 log units) from the limit.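

In this assay, 4-chlorophenyl in place of 2-chlorophenyl gives an at least 3.3-fold higher number from compound 1 to compound 3 (0.52 log units; beyond the scatter), and this is a lower bound. Compound 2 left open the idea that any chlorophenyl group set directly on the amide nitrogen would bring back a measurable value, but compound 3 goes against that idea, so among these compounds the place of the chlorine on the ring matters, and only the 2-chlorophenyl group of compound 1 gives a measured number. The step from compound 2 to compound 3 cannot be read because both of its values are limits: the limit of > 100000 nM in this assay, at which 2 of the 3 values shown sit.

Going by these compounds, with only compound 1 giving a measured number, how far compound 2 and compound 3 lie beyond that limit stays unknown. On these data alone, it also stays open whether the chlorine itself counts, or whether a plain phenyl group, a 2-bromophenyl group or a 2-methoxyphenyl group on the amide nitrogen would give a number like that of compound 1, or a lower one.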